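Two chloro groups on the benzyl of compound 2

The source may hold more compounds than are shown below. What is called first, only, known or untested is meant among the compounds shown, and "the series" means these compounds.

compound 1 (`CN(C)Cc1ccc2nc(NC(=O)N/N=C/c3cn(Cc4ccccc4Cl)c4ccccc34)sc2c1`): 1080 nM
compound 2 (`CN(C)Cc1ccc2nc(NC(=O)N/N=C/c3cn(Cc4ccccc4)c4ccccc34)sc2c1`): 2900 nM
compound 3 (`CC1CCN(Cc2ccc3nc(NC(=O)N/N=C/c4cn(Cc5ccccc5)c5ccccc45)sc3c2)CC1`): 2340 nM

In a functional assay on A549 cells (Homo sapiens) for cytotoxicity, read by MTT assay, with a stated time of 72 h (a higher number here means a weaker inhibitor, a lower number a stronger inhibitor), compound 2 gives 2900 nM and lies within the scatter of compound 3, while its number is higher than that of compound 1. The unmeasured compound 4 (`CN(C)Cc1ccc2nc(NC(=O)N/N=C/c3cn(Cc4ccc(Cl)c(Cl)c4)c4ccccc34)sc2c1`) turns the benzyl of compound 2 into 3,4-dichlorobenzyl (3,4-dichlorophenyl in place of phenyl on a saturated chain carbon bound to an aromatic nitrogen). The closest guide is a 2.7-fold higher number from compound 1 to compound 2 (0.43 log units; beyond the scatter) as hydrogen replaces chloro on an aromatic carbon. Read in reverse, this step suggests that adding chloro may lower the number. The other measured step (a 1.2-fold lower number from compound 2 to compound 3 (0.09 log units; within the scatter)) concerns the dimethylamino group, which compound 4 keeps, so it offers little guidance here. Among the measured compounds shown here, no measured compound carries the 3,4-dichlorophenyl group, so the size of the change remains uncertain. A modest fall in the number is expected (a 2.9-fold lower number from compound 2 to compound 4 (0.46 log units; beyond the scatter)). In this assay compound 4 is estimated at 1000 nM with an expected range from 350 nM to 2800 nM around that middle.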

Compound 4, half-maximal inhibitory concentration: 940 nM
Beside the measured number, compound 4's estimate is 1.1-fold (0.03 log units) above it, and the stated range covers the measured number.
By their numbers in this assay, from the lowest: compounds 4 and 1 (each within the scatter of the next); then compounds 3 and 2 (each within the scatter of the next).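

In this assay, replacing phenyl with 3,4-dichlorophenyl on the saturated chain carbon bound to the aromatic nitrogen gives a 3.1-fold lower number from compound 2 to compound 4 (0.49 log units; beyond the scatter) and so joins the 2-chlorophenyl of compound 1 as a second chlorinated ring with a lower number than the plain phenyl of compound 2. The two chlorinated rings cannot be told apart, since a 1.1-fold lower number from compound 1 to compound 4 (0.06 log units; within the scatter) is the whole of the difference, and the extra chloro group of compound 4 buys nothing this assay can resolve. Nothing measured here explains what the chloro groups do at this position.

As far as these compounds go, whether a methoxy group or a nitrile on this ring would also lower the number remains open. So does what happens when 3,4-dichlorobenzyl is paired with the 4-methylpiperidin-1-yl group of compound 3.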